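Carbamate series: phenyl in place of tert-butyl

The compounds below may be only part of what the source reports. "The series", "measured", "known", "first", "only" and "open" are said of these compounds alone.

Measured so far in an assay on HEK293 cells for inhibition of N-acylethanolamine-hydrolyzing acid amidase (Homo sapiens), read by fluorescence, with stated times of 10 min and 50 min; a higher number here means a weaker inhibitor, a lower number a stronger inhibitor:
compound 1 `CC(C)(C)c1ccc(COC(=O)N[C@H]2CNC2=O)cc1`, 310 nM
compound 2 `O=C(N[C@H]1CNC1=O)OCc1ccc2c(c1)CCCC2`, 140 nM
compound 3 `CC(OC(=O)N[C@H]1CNC1=O)c1ccc(C2CCCCC2)cc1`, 4470 nM

Compound 1 gives the second highest number of the three in this assay. Compound 2 gives a lower number than compound 1, beyond the scatter, and compound 3 a far higher number, also beyond the scatter. Going by the values given here, no pair that differs in only one place has been measured, so no single step is known.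

Compound 4 `O=C(N[C@H]1CNC1=O)OCc1ccc(-c2ccccc2)cc1` is next; compared with compound 1 the change is phenyl in place of tert-butyl on an aromatic carbon. Among the compounds with values here, with no matched step as a guide, the expectation is a small change from compound 1, toward a lower number if anything, as a 1.6-fold lower number from compound 1 to compound 4 (0.19 log units; within the scatter). Compound 4 is estimated at 200 nM, within 60 nM to 700 nM.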

Compound 4, half-maximal inhibitory concentration: 513 nM
Beside the measured number, compound 4's estimate is 2.6-fold (0.41 log units) below it; the range from low to high includes it.
By their numbers in this assay, from the lowest: compound 2; then compounds 1 and 4 (each within the scatter of the next); then compound 3.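

In this assay, going by these compounds alone, the first matched step at this position is a 1.7-fold higher number from compound 1 to compound 4 (0.22 log units; within the scatter), for phenyl in place of tert-butyl on an aromatic carbon. This position therefore takes either the ring-free tert-butyl or the phenyl ring without a change beyond the scatter. No evidence is available on why these two groups read alike.

Still open, as far as these compounds go, is whether a group bearing nitrogen or oxygen at this carbon, such as a pyridine ring, a methoxy or an amine, would hold the number or move it beyond the scatter.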